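This account rests on a few compounds, and the source may have more. Where it says the series, first, only, none or still open, it means among the compounds named here.

Measured so far:
- compound 1 `Cc1ccc(CS(=O)(=O)/C(=C/c2cc(C)cc(C)c2)C(=O)c2ccc(Cl)cc2)cc1`: 10000 nM
- compound 2 `Cc1ccc(CS(=O)(=O)/C(=C/c2ccc(N(C)C)cc2)C(=O)c2ccc(Cl)cc2)cc1`: 50000 nM

In a functional assay on DU-145 cells (Homo sapiens) for inhibition, read by trypan blue exclusion, with a stated time of 96 h (on this read-out higher numbers stand for weaker inhibition of growth and lower numbers for stronger inhibition of growth), compound 2 gives 50000 nM, the higher of the two numbers and so the weaker inhibition of growth. Compound 1 stands at 10000 nM.

The next compound to be measured is compound 3 `Cc1ccc(CS(=O)(=O)/C(=C/c2sccc2C)C(=O)c2ccc(Cl)cc2)cc1`. The change leading to it is 3-methylthiophen-2-yl in place of 4-(dimethylamino)phenyl on a double-bonded chain carbon bound to a double-bonded chain carbon.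

Among the measured compounds shown here, only one measured step bears on this place: a 5.0-fold higher number from compound 1 to compound 2 (0.70 log units; beyond the scatter). That step is modest but beyond the scatter, and it shows 4-(dimethylamino)phenyl as the less favourable of the two groups tested there. For the measured compounds named here, no measured compound carries a 3-methylthiophen-2-yl group, so the evidence is thin. Going by the values given here, a modest move toward stronger inhibition in this assay is expected, of about the size of the one measured step, with a return to the level of compound 1 as the simplest assumption.

The expected step is a 3.3-fold lower number from compound 2 to compound 3 (0.52 log units; beyond the scatter). For compound 3 the estimated value is 15000 nM, with an expected range of 4000 nM to 50000 nM.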

Compound 3, concentration for 50% growth inhibition: 25000 nM
The estimate for compound 3 lay 1.7-fold (0.22 log units) below the measured number; the range from low to high includes it.
By their numbers in this assay, from the lowest: compound 1; then compounds 3 and 2 (each within the scatter of the next).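

In this assay the 3-methylthiophen-2-yl group on a double-bonded chain carbon bound to a double-bonded chain carbon cannot be told apart from 4-(dimethylamino)phenyl: the step of a 2.0-fold lower number from compound 2 to compound 3 (0.30 log units; within the scatter) gives no ordering of the two, despite the change in ring type and heavy-atom count. Set against 3,5-dimethylphenyl, the same group does separate, with a 2.5-fold higher number from compound 1 to compound 3 (0.40 log units; beyond the scatter) as a modest loss of growth inhibition, so compound 1 now stands apart from both other compounds, its steps to each lying beyond the scatter. Nothing on hand offers an explanation for this pattern.

Going by these compounds, all three compounds keep the rest of the shared core unchanged, so it remains open whether the same pattern at this place would hold with a different group elsewhere on the core. Also open, on these data alone, is how an unsubstituted phenyl, a carboxylic acid or a morpholine at this place would compare, and whether any group gives stronger inhibition of growth than compound 1 at 10000 nM.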